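A few compounds are considered here, and "the series" means these few. Any claim that something is new, unique, unknown or untested is made for them only; others in the source may bear on it.

Compound 1 `CC(C)(C)c1ncc2c(N)c(C#N)c(N)nc2n1` is the simplest member of a small set. In a physicochemical assay for solubility, in phosphate buffer, with a stated time of 18 h (on this read-out lower numbers stand for lower solubility and higher numbers for higher solubility), compound 1 gives 37200 nM, the lowest of the three numbers, though both others lie within the scatter of it: compound 2 `CC(C)(C)c1nc(-c2cccs2)c2c(N)c(C#N)c(N)nc2n1` gives 56000 nM and compound 3 `CC(C)(C)c1nc(-c2ccsc2)c2c(N)c(C#N)c(N)nc2n1` gives 40000 nM. The step of a 1.5-fold higher number from compound 1 to compound 2 (0.18 log units; within the scatter) and the step of a 1.1-fold higher number from compound 1 to compound 3 (0.03 log units; within the scatter) both stay within the scatter, as does a 1.4-fold lower number from compound 2 to compound 3 (0.15 log units; within the scatter). Compound 4 `CC(C)(C)c1nc(-c2ncc[nH]2)c2c(N)c(C#N)c(N)nc2n1` differs from compound 1 in one place: 1H-imidazol-2-yl in place of hydrogen on an aromatic carbon. The two measured steps that place a five-membered aromatic ring at the same position bear directly on this change, and neither moved the number beyond the scatter. The entering ring carries a hydrogen-bond donor and a hydrogen-bond acceptor, so the comparison is not exact. Even so, the expectation is a step no larger than the scatter, at most a slightly higher number, a 1.2-fold higher number from compound 1 to compound 4 (0.08 log units; within the scatter). Compound 4 is therefore estimated at 45000 nM, with a range from 20000 nM to 100000 nM.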

Compound 4, solubility: < 1000 nM
Compound 4 gave a limit, no number; the forecaster's own chance of this, stated with the estimate: 5%; at least 45-fold (1.65 log units) between middle value and limit.
By their numbers in this assay, from the lowest: compounds 1, 3 and 2 (each within the scatter of the next). At a limit, below all of these: compound 4.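

In this assay, this position, on an aromatic carbon next to the ring nitrogen, turns out to respond strongly to which five-membered aromatic ring it carries, something the two thiophene compounds could not reveal. Introducing 1H-imidazol-2-yl gives an at least 37-fold lower number from compound 1 to compound 4 (1.57 log units; beyond the scatter), and the comparisons with the thiophene compounds agree, at an at least 40-fold lower number from compound 3 to compound 4 (1.60 log units; beyond the scatter) and an at least 56-fold lower number from compound 2 to compound 4 (1.74 log units; beyond the scatter). The value of compound 4 is a limit and not a number: the limit of < 1000 nM in this assay, at which 1 of the 4 values shown sits.

The compounds shown do not separate the possible sources of this large step, such as the ring's hydrogen-bond donor or its second nitrogen. A 1-methylimidazol-2-yl group, which keeps both ring nitrogens but replaces the ring's nitrogen-bound hydrogen, or a pyridin-2-yl ring at the same place would be the informative comparison.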